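Chloro on the shared core: two parallel steps

A few compounds are considered here, and "the series" means these few. Any claim that something is new, unique, unknown or untested is made for them only; others in the source may bear on it.

Compound 3 `Clc1ccc(Sc2c(-c3ccc(Cl)cc3)[nH]c3ccccc23)cc1` and compound 1 `Clc1ccc(Sc2c(-c3ccc(Cl)cc3)[nH]c3ccc(Cl)cc23)cc1` differ by one change, (chloro in place of hydrogen on an aromatic carbon). In a functional assay on Hs 683 cells (Homo sapiens) for inhibition, read by MTT assay, with a stated time of 72 h (a higher number here means a weaker inhibitor of growth, a lower number a stronger inhibitor of growth), compound 3 gives 31000 nM, and compound 1 gives 31000 nM; the step is no change at the digits printed from compound 3 to compound 1 (within the scatter). Compound 2 `CCOC(=O)C1CCN(C(=S)Sc2c(-c3ccc(Br)cc3)[nH]c3ccccc23)CC1` differs from compound 3 in more than one place; the difference between the two cores is not broken down here. In this assay compound 2 gives 36000 nM, a number that sits within the scatter of those of compound 1 and compound 3. Compound 4 `CCOC(=O)C1CCN(C(=S)Sc2c(-c3ccc(Br)cc3)[nH]c3ccc(Cl)cc23)CC1` is the next member, derived from compound 2 by the change (chloro in place of hydrogen on an aromatic carbon). Among the measured compounds shown here, this is the same change as the one from compound 3 to compound 1, made at the same place of the shared core. For compound 4 the expected step is a 1.0-fold lower number from compound 2 to compound 4 (0.01 log units; within the scatter), because the matching step was no change at the digits printed from compound 3 to compound 1 (within the scatter). The estimate for compound 4 in this assay is therefore 35000 nM, with a range from 18000 nM to 70000 nM.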

Compound 4, concentration for 50% growth inhibition: 36000 nM
Compound 4: middle estimate off by 1.0-fold (0.01 log units), on the low side; the measured number falls inside the stated range.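

In this assay the step for chloro in place of hydrogen on an aromatic carbon is no change at the digits printed from compound 2 to compound 4 (within the scatter), and it matches the earlier one on the other core: the same change on two cores in this assay, no change at the digits printed (within the scatter) from compound 3 to compound 1 and no change at the digits printed (within the scatter) from compound 2 to compound 4, 1.0-fold (0.00 log units) apart, within the scatter of two such steps. Across these two cores the change therefore carries over as a null result, with neither core showing a step beyond the scatter. This does not show that a step of real size would transfer, since two flat steps test agreement only where nothing moved, and the evidence covers a single carbon, a single group and a single cell line.

Open, going by these compounds, is whether a different group on the same aromatic carbon, such as an amine, a methoxy or a carboxylic acid, would move the number beyond the scatter on either core. Also open, on these data alone, is whether a carboxylic acid in place of the ethyl ester of compound 2 would alter the response to chloro.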